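Chloropyridine Ether Gives Way to a Trifluoromethylphenyl Ether

The compounds below may be only part of what the source reports. "The series", "measured", "known", "first", "only" and "open" are said of these compounds alone.

Within the data shown here, compound 1 `CC(CCNC(=O)c1c(Cl)cncc1Cl)N1CCC(C(Oc2ncccc2Cl)c2ccc(C(F)(F)F)cc2)CC1` is the only compound here with a full number in an ADME assay on PBMC cells (Homo sapiens) for cytotoxicity (on this read-out higher numbers stand for lower toxicity in this test and lower numbers for higher toxicity in this test), where compound 1 gives 16700 nM. Compound 2 `CCO/N=C(/c1ccc(Br)cc1)C1CCN(C(CC)CCNC(=O)c2c(C)cc[n+]([O-])c2C)CC1` reaches only a limit of this assay, > 177000 nM, so it shows no number of its own. Compound 3 `CC(CCNC(=O)c1c(Cl)cncc1Cl)N1CCC(C(Oc2ccccc2C(F)(F)F)c2ccc(C(F)(F)F)cc2)CC1` differs from compound 1 in a single place: 2-(trifluoromethyl)phenyl in place of 3-chloropyridin-2-yl on an oxygen on a saturated carbon. Among the measured compounds shown here, no step between two measured compounds is available to calibrate this change, so the expectation rests on compound 1 alone. The step of a 1.4-fold lower number from compound 1 to compound 3 (0.14 log units; within the scatter) is expected to be small, leaning towards higher toxicity but hardly beyond the usual scatter. Compound 3 is therefore estimated at 12000 nM, with a likely range from 4000 nM to 40000 nM.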

Compound 3, half-maximal cytotoxic concentration: 12500 nM
Compound 3: the middle estimate sits 1.0-fold (0.02 log units) below what was measured, and the stated range covers the measured number.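

In this assay, 2-(trifluoromethyl)phenyl in place of 3-chloropyridin-2-yl gives a 1.3-fold lower number from compound 1 to compound 3 (0.13 log units; within the scatter). This position on the oxygen therefore tolerates a ring of carbon only, so in this pair the ring nitrogen of 3-chloropyridin-2-yl is not needed to keep the number at this level. Nothing shown here accounts for this small step. Going by these compounds, whether an amine or a carboxylic acid on this ring would move the number beyond the scatter stays open, as does the effect of a longer chain in place of the ring.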